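A few compounds are considered here, and "the series" means these few. Any claim that something is new, unique, unknown or untested is made for them only; others in the source may bear on it.

Measured in a functional assay on HeLa cells (Homo sapiens) for inhibition, read by sulforhodamine B assay; a higher number here means a weaker inhibitor, a lower number a stronger inhibitor:
- compound 1 `O=C1C(Nc2ccccc2)=CC(=O)c2c1nc1n2[C@H]2OC[C@@H](O)[C@H]2OC1`: > 8000 nM (a limit)
- compound 2 `O=C1C=C(N2CCC2)C(=O)c2c1nc1n2[C@H]2OC[C@@H](O)[C@H]2OC1`: > 16000 nM (a limit)
- compound 3 `O=C1C=C(Nc2ccccc2F)C(=O)c2c1nc1n2[C@H]2OC[C@@H](O)[C@H]2OC1`: 5120 nM

Compound 1 stands at a limit and has no number, as the limit of > 8000 nM in this assay, at which 1 of the 3 values shown sits, records. Compound 2 is also known only by a limit, as the limit of > 16000 nM in this assay, at which 1 of the 3 values shown sits, records. Compound 3 is the only one of the three with a measured number.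

The next compound is compound 4 `Cc1ccc(NC2=CC(=O)c3c(nc4n3[C@H]3OC[C@@H](O)[C@H]3OC4)C2=O)cc1`, which keeps the core of compound 1 and changes its anilino group to (4-methylphenyl)amino: methyl in place of hydrogen on an aromatic carbon. This places methyl in place of hydrogen on an aromatic carbon, para to a large group.

Among the compounds with values here, no measured step makes this same change. Within the data shown here, the one step available, an at least 3.1-fold lower number from compound 2 to compound 3 (0.49 log units; beyond the scatter), exchanges a whole group on the core and shows only that the group on that carbon can move the number beyond the scatter. A single added methyl is a far smaller change, so a step of that size is not expected here. With compound 1 known only as a limit, no direction can be firmly expected, and a step within the scatter is the likeliest outcome. The expected step is a number no higher from compound 1 to compound 4 (the limit leaves the size open). Compound 4 is estimated at 8000 nM, with an expected range from 3500 nM to 20000 nM.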

Compound 4, half-maximal inhibitory concentration: 6590 nM
The estimate for compound 4 lay 1.2-fold (0.08 log units) above the measured number; the measured number falls inside the stated range.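

With methyl on an aromatic carbon, para to a large group, the series gains a measured number at this position: in this assay compound 4 gives 6590 nM. The change reads as an at least 1.2-fold lower number from compound 1 to compound 4 (0.08 log units; that floor lies within the scatter), so only a floor is known, and the data do not show that this methyl moves the number beyond the scatter, nor that it leaves the number unchanged. From the compounds shown here alone, the true size of the step stays open because compound 1 is known only as a limit, and an added methyl could have done anything from very little to much more: the limit of > 8000 nM in this assay, at which 1 of the 4 values shown sits.

The compounds shown leave open whether another group on this same aromatic carbon, such as methoxy, chlorine or a carboxylic acid, would give a number clearly lower or higher than that of compound 4 in this assay, and whether methyl would read the same on another carbon of that six-membered ring. They also leave open what a longer chain, such as benzylamino or phenethylamino in place of the anilino group, would give on the core of compound 1.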